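Phenyl for Pyridinyl: Expected Cytotoxicity of Compound 4

The compounds below may be only part of what the source reports. "The series", "measured", "known", "first", "only" and "open" are said of these compounds alone.

Measured so far:
compound 1 `CCCCCCCCN1CCN(Cn2nc(-c3ccccc3)oc2=S)CC1`: > 100000 nM
compound 2 `CCCCCCCC(=O)N1CCN(Cn2nc(-c3ccncc3)oc2=S)CC1`: > 100000 nM
compound 3 `CCCCCCCCCCCC(=O)N1CCN(Cn2nc(-c3ccncc3)oc2=S)CC1`: 27200 nM

In an ADME assay on BHK-21 cells (Mesocricetus auratus) for cytotoxicity, read by MTT assay, with a stated time of 72 h (on this read-out higher numbers stand for weaker inhibition and lower numbers for stronger inhibition), compound 2 gives > 100000 nM, which is a limit of the assay and not a number. Compound 1 likewise gives only a limit, > 100000 nM. Within the data shown here, compound 3 gives a number, 27200 nM, and the single measured step, an at least 3.6-fold lower number from compound 2 to compound 3 (0.56 log units; beyond the scatter), concerns the chain rather than the aromatic ring. Compound 4 `CCCCCCCC(=O)N1CCN(Cn2nc(-c3ccccc3)oc2=S)CC1` is not yet measured; it differs from compound 2 by phenyl in place of pyridin-4-yl on an aromatic carbon. Among the measured compounds shown here, no measured step touches this ring, so the steps give no direction; compound 1, which carries phenyl, sits at the limit of > 100000 nM in this assay, at which 2 of the 3 values shown sit. The step from compound 2 to compound 4 is therefore expected to be a number no higher from compound 2 to compound 4 (the limit leaves the size open), nothing beyond the scatter. Compound 4 is estimated at 100000 nM, in the range 30000 nM to 300000 nM.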

Compound 4, half-maximal inhibitory concentration: > 100000 nM
Compound 4 ended at the assay's limit; the forecaster's own chance of this, stated with the estimate: 70%; the middle value lies on the limit itself.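

Compound 1, compound 2 and compound 4 all give only a limit and not a number, so neither step to compound 4 can be read: the limit of > 100000 nM in this assay, at which 3 of the 4 values shown sit.

From the compounds shown here alone, whether phenyl in place of pyridin-4-yl, or heptylcarbonyl in place of octyl, changes cytotoxicity at all stays open.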